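Cyclohexyl for 3,4-dimethoxybenzyl, starting from a limit

The compounds below may be only part of what the source reports. "The series", "measured", "known", "first", "only" and "open" are said of these compounds alone.

Measured in a functional assay on SK-BR-3 cells (Homo sapiens) for antiproliferative activity, read by MTT assay, with a stated time of 72 h; on this read-out lower numbers stand for stronger inhibition and higher numbers for weaker inhibition:
- Compound 1 `C/C=C1/[C@H](O[C@@H]2O[C@H](CO)[C@@H](O)[C@H](O)[C@H]2O)OC=C(C(=O)OC)[C@H]1CC(=O)OCc1ccco1`: > 15000 nM (a limit)
- Compound 2 `C/C=C1/[C@H](O[C@@H]2O[C@H](CO)[C@@H](O)[C@H](O)[C@H]2O)OC=C(C(=O)OC)[C@H]1CC(=O)OCCCc1ccc(OC)c(OC)c1`: > 20000 nM (a limit)

Compound 2 stands at > 20000 nM, which is a limit of the assay and not a number. Neither measured compound has yet given a number in this assay.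

Compound 3 `C/C=C1/[C@H](O[C@@H]2O[C@H](CO)[C@@H](O)[C@H](O)[C@H]2O)OC=C(C(=O)OC)[C@H]1CC(=O)OCCC1CCCCC1` differs from compound 2 in one place: cyclohexyl in place of 3,4-dimethoxybenzyl on a saturated chain carbon, two bonds along the chain from an oxygen next to a carbonyl group. It has cyclohexyl in place of 3,4-dimethoxybenzyl on a saturated chain carbon, two bonds along the chain from an oxygen next to a carbonyl group.

Going by the values given here, only one measured step bears on this change: a step that the two limits leave unreadable from compound 1 to compound 2. It has no readable size, so it offers no support for a shift in either direction. The expected step, a step that the limit leaves unreadable from compound 2 to compound 3, is therefore none beyond the scatter. Compound 3 is expected near 25000 nM, with an estimated range from 10000 nM to 60000 nM.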

Compound 3, half-maximal inhibitory concentration: 2000 nM
The estimate for compound 3 lay 13-fold (1.10 log units) above the measured number; measured number outside the range, below it.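

In this assay, going by these compounds alone, compound 3 is the first compound here to give a number and not a limit, which shows that this place on the side chain can carry a group that gives a measurable read-out: cyclohexyl in place of 3,4-dimethoxybenzyl gives an at least 10-fold lower number from compound 2 to compound 3 (1.00 log units; beyond the scatter), and cyclohexylmethyl in place of furan-2-yl gives an at least 7.5-fold lower number from compound 1 to compound 3 (0.87 log units; beyond the scatter). The value of compound 1 is a limit of the assay, so the second step has only a lower bound: the limit of > 15000 nM in this assay, at which 1 of the 3 values shown sits. The value of compound 2 is also a limit, so the first step has only a lower bound as well: the limit of > 20000 nM in this assay, at which 1 of the 3 values shown sits.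

The compounds shown do not separate the loss of the two methoxy groups from the change of the aromatic ring to cyclohexyl, which an unsubstituted 2-phenylethyl group would address. They also leave open how a longer chain before the cyclohexyl ring, or an amine within that ring, would read in this assay.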